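A few compounds are considered here, and "the series" means these few. Any claim that something is new, unique, unknown or untested is made for them only; others in the source may bear on it.

Compound 1 `CC[C@@H]1C[C@H](CC)CN(CCCNC(=O)C2CCN(Cc3nc(-c4ccccc4C)oc3C)CC2)C1` is the reference point of this set. In an ADME assay on Huh7.5.1 cells (Homo sapiens) for cytotoxicity, read by ATP content, with a stated time of 48 h (on this read-out higher numbers stand for lower toxicity in this test and lower numbers for higher toxicity in this test), compound 1 gives 3470 nM, the lowest of the three numbers shown. Compound 3 `CC[C@@H]1C[C@H](CC)CN(CCCNC(=O)C2CCN(Cc3nc(-c4c(F)cccc4F)oc3C)CC2)C1` gives 12600 nM, and compound 2 `Cc1oc(-c2ccccc2Cl)nc1CN1CCC(C(=O)NCCCN2C[C@H](C)C[C@H](C)C2)CC1` gives 16500 nM. Going by the values given here, the one single-point step, a 3.6-fold higher number from compound 1 to compound 3 (0.56 log units; beyond the scatter), involves the aromatic substituent only; compound 2 differs from compound 1 in two places, so its value merely shows that the higher number is compatible with changes elsewhere in the molecule.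

Compound 4 `Cc1ccccc1-c1nc(CN2CCC(C(=O)NCCCN3CCCC(CC(C)C)C3)CC2)c(C)o1` differs from compound 1 in a different place: a group of 10 heavy atoms (9 carbon, 1 nitrogen; one six-membered non-aromatic ring with 1 hetero atom) in place of a group of 10 heavy atoms (9 carbon, 1 nitrogen; one six-membered non-aromatic ring with 1 hetero atom), on a saturated chain carbon, three bonds along the chain from an amide-type nitrogen. Among the compounds with values here, no measured step touches the saturated chain or the ring at its end, so nothing here bears directly on this change, and the two compounds share the same atoms joined differently. Compound 4 is therefore expected to sit close to compound 1, with a step of a 1.3-fold higher number from compound 1 to compound 4 (0.11 log units; within the scatter) that need not exceed the scatter, perhaps drifting slightly toward the higher numbers of compounds 2 and 3. The estimate for compound 4 is 4500 nM, within 1500 nM to 14000 nM.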

Compound 4, half-maximal cytotoxic concentration: 4640 nM
Beside the measured number, compound 4's estimate is 1.0-fold (0.01 log units) below it; low and high end bracket the measured number.
By their numbers in this assay, from the lowest: compounds 1 and 4 (each within the scatter of the next); then compounds 3 and 2 (each within the scatter of the next).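

Going by these compounds alone, the only measured step at this place, on a saturated chain carbon, three bonds along the chain from an amide-type nitrogen, gives in this assay a 1.3-fold higher number from compound 1 to compound 4 (0.13 log units; within the scatter). Replacing 3,5-diethylpiperidin-1-yl, with its 2 defined stereocentres, by a group of the same atoms joined differently therefore stays within the scatter, whereas the step on the aromatic substituent, a 3.6-fold higher number from compound 1 to compound 3 (0.56 log units; beyond the scatter), lies beyond it. Nothing available explains why this rearrangement leaves the number within the scatter.

The compounds shown leave open whether a morpholine, a primary amine or a carboxylic acid at the end of this chain would also stay within the scatter. They also leave open whether the entering group would behave the same way alongside the 2,6-difluorophenyl substituent.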